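Series notes: sulfonyl swap on the triazolylmethyl sulfonamide

This account rests on a few compounds, and the source may have more. Where it says the series, first, only, none or still open, it means among the compounds named here.

Measured so far:
- compound 1, `Cc1ccc(S(=O)(=O)n2cc(CN(Cc3cn(Cc4ccccc4)nn3)S(=O)(=O)c3ccccc3)c3ccccc32)cc1`: -18%
- compound 2, `Fc1ccc(CNCc2cccc(F)c2F)cc1`: -53.4%
- compound 3, `Cc1ccc(S(=O)(=O)n2cc(CN(Cc3cn(Cc4ccc(F)cc4)nn3)S(C)(=O)=O)c3ccccc32)cc1`: -19.5%

In a functional assay on 3T3-L1 cells (Mus musculus) for inhibition, with a stated time of 20 min, tested at 20 uM (on this read-out lower numbers stand for less inhibition and higher numbers for more inhibition at the one concentration tested (going by the name of the read-out)), compound 3 gives -19.5%, the second highest of the three numbers. Compound 1 lies nearest, within the usual scatter, so no order between the two can be read. Compound 2 lies furthest, beyond the scatter, with the lowest number of the set.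

The next compound, compound 4, `Cc1ccc(S(=O)(=O)n2cc(CN(Cc3cn(Cc4ccc(F)cc4)nn3)S(=O)(=O)c3ccccc3)c3ccccc32)cc1`, differs from compound 3 in one place: phenyl in place of methyl on a sulfonyl sulfur. The same difference, cut one bond further out, reads methylsulfonyl to phenylsulfonyl.

Among the measured compounds shown here, no measured pair in this set differs in one place, so the size of this step has no direct precedent. Compound 1 carries a phenylsulfonyl and gives -18%, a number close to that of compound 3, which argues against a large swing. The step from compound 3 to compound 4 is expected to be a number 0.5 percentage points higher from compound 3 to compound 4 (within the scatter), none beyond the scatter.

Compound 4 is therefore estimated at -19%, with a range from -36% to -2%.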

Compound 4, a percentage reported as inhibition, at one concentration (the size of the read-out at that concentration, not a potency): -21%
The estimate for compound 4 lay 2 percentage points above the measured number; the measured number falls inside the stated range.
By their numbers in this assay, from the lowest: compound 2; then compounds 4, 3 and 1 (each within the scatter of the next).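

Phenyl in place of methyl on a sulfonyl sulfur gives, in this assay, a number 1.5 percentage points lower from compound 3 to compound 4 (within the scatter); this is the first direct reading at this position, and methyl and phenyl cannot be told apart there, even though the phenyl brings a six-membered aromatic ring and more heavy atoms. Fluoro in place of hydrogen on an aromatic carbon gives a number 3 percentage points lower from compound 1 to compound 4 (within the scatter), so that place cannot be separated by this read-out either. Nothing at hand bears on why these values sit so close.

With only methyl and phenyl shown on the sulfonyl sulfur, it remains open whether this flat reading extends to other groups there, such as a dimethylamino group or a butyl chain. Also open, from the compounds shown here alone, is whether any group at this position would give a step beyond the scatter.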